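Butyl for cyclohexyl on the imine chain of compound 1

This account rests on a few compounds, and the source may have more. Where it says the series, first, only, none or still open, it means among the compounds named here.

Compound 1 `C/C(=N\CC1CCCCC1)c1c(O)c2ccccc2[nH]c1=O` is the reference point. In an assay on isolated protein for inhibition of myosin-2 (Bos taurus), read by spectrophotometry, with a stated time of 24 min (a lower number here means a stronger inhibitor, a higher number a weaker inhibitor), compound 1 reaches only a limit of >= 100000 nM, not a number. The two other measured members carry a different core: compound 2 `C/C(=N\Nc1ccccc1)c1c(O)c2ccccc2oc1=O` gives 27000 nM in this assay, and compound 3 `C/C(=N\CC(C)C)c1c(O)c2ccccc2oc1=O` gives 34000 nM. Among the compounds with values here, the single step between measured compounds is a 1.3-fold higher number from compound 2 to compound 3 (0.10 log units; within the scatter), which lies within the scatter. Compound 4 `CCCCC/N=C(\C)c1c(O)c2ccccc2[nH]c1=O` differs from compound 1 by butyl in place of cyclohexyl on a saturated chain carbon bound to a double-bonded nitrogen. Within the data shown here, this change is not the one made between compound 2 and compound 3, and it sits on the core of compound 1 rather than on that of compound 2, so the measured step bears on it only loosely; what it does show is a swap on the same double-bonded nitrogen that stayed within the scatter. No step beyond the scatter is expected in this assay from compound 1 to compound 4, and since compound 1 sits at the limit of >= 100000 nM in this assay, at which 1 of the 3 values shown sits, compound 4 is expected to return a limit as well, most likely. Compound 4 is estimated at 100000 nM, with a range from 40000 nM to 300000 nM, which means an expected step of a number no higher from compound 1 to compound 4 (the limit leaves the size open).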

Compound 4, half-maximal inhibitory concentration: >= 100000 nM
Compound 4 ended at the assay's limit; the forecaster's own chance of this, stated with the estimate: 60%; the middle value lies on the limit itself.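

Compound 1 and compound 4 both end at a limit of this assay rather than at a number, so no step can be read between them: the limit of >= 100000 nM in this assay, at which 2 of the 4 values shown sit.

The compounds shown leave open whether butyl in place of cyclohexyl changes inhibition at all on the core of compound 1.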